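Aryl swap on the triazole nitrogen: compound 4 expected

A few compounds are considered here, and "the series" means these few. Any claim that something is new, unique, unknown or untested is made for them only; others in the source may bear on it.

Compound 1 `C/C(=C\CC/C(C)=C/CC[C@@H]1[C@@]2(C)CCC(=O)C(C)(C)[C@H]2CC[C@@]1(C)O)CC/C=C(\C)C(=O)OCc1cn(-c2ccc(F)c(Cl)c2)nn1` gives > 150000 nM in an ADME assay on L132 cells (Homo sapiens) for cytotoxicity, read by MTT assay, with a stated time of 48 h; on this read-out higher numbers stand for weaker inhibition and lower numbers for stronger inhibition.
Compound 2 `C/C(=C\CC/C(C)=C/CC[C@@H]1[C@@]2(C)CCC(=O)C(C)(C)[C@H]2CC[C@@]1(C)O)CC/C=C(\C)C(=O)OCc1cn(-c2cccc(C)c2)nn1` gives > 150000 nM in this assay.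
Compound 3 `C/C(=C\CC/C(C)=C/CC[C@@H]1[C@@]2(C)CCC(=O)C(C)(C)[C@H]2CC[C@@]1(C)O)CC/C=C(\C)C(=O)OCc1cn([C@@H]2C[C@@H](n3cc(C)c(=O)[nH]c3=O)O[C@H]2CO)nn1` gives 115000 nM in this assay.

In this assay compound 2 reaches only a limit of the assay, > 150000 nM, not a number. Among the measured compounds shown here, compound 1 sits at the same kind of limit, so the step that the two limits leave unreadable from compound 1 to compound 2 cannot be read; compound 3 is the only one with a measured number. The change to compound 4 `C/C(=C\CC/C(C)=C/CC[C@@H]1[C@@]2(C)CCC(=O)C(C)(C)[C@H]2CC[C@@]1(C)O)CC/C=C(\C)C(=O)OCc1cn(-c2ccccc2F)nn1` is 2-fluorophenyl in place of 3-methylphenyl on an aromatic nitrogen. For the measured compounds named here, no measured step bears on this change, and the limit of > 150000 nM in this assay, at which 2 of the 3 values shown sit, shows that the two aryl variants so far did not reach a measurable value. The expected step of a number no higher from compound 2 to compound 4 (the limit leaves the size open) is therefore none beyond the scatter, and compound 4 is estimated at 150000 nM, with a range from 90000 nM to 300000 nM.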

Compound 4, half-maximal inhibitory concentration: > 150000 nM
Compound 4: only a limit was reported; the forecaster's own chance of this, stated with the estimate: 70%; the middle value lies on the limit itself.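

Compound 4 gives > 150000 nM, a limit of the assay and not a number. Compound 1 and compound 2 also stop at limits, so no step among these three can be read. The compounds shown leave open whether these three differ at all in this assay.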